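A Halogen Swap on the Shared Core

A few compounds are considered here, and "the series" means these few. Any claim that something is new, unique, unknown or untested is made for them only; others in the source may bear on it.

Measured compounds in a toxicity assay on the whole organism with Rattus norvegicus as the target, at a dose of 100 mg/kg by the oral route; on this read-out lower numbers stand for a weaker effect and higher numbers for a stronger effect at the one dose given:
compound 1 `COc1ccc(OCC2=NCCO2)cc1` gives 50%
compound 2 `Brc1ccccc1OCC1=NCCO1` gives 70%
compound 3 `O=[N+]([O-])c1ccc(OCC2=NCCO2)cc1` gives 50%

Compound 2 stands highest of the three numbers in this assay. Compound 1 and compound 3 both sit lower by a gap beyond the scatter, and the two of them lie within the scatter of each other. Among the measured compounds shown here, the one step that can be compared, no change at the digits printed from compound 1 to compound 3 (within the scatter), shows that exchanging one group for another on the aromatic carbon left the read-out unchanged.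

Compound 4 `Fc1ccccc1OCC1=NCCO1` is not yet measured. It differs from compound 2 as follows: fluoro in place of bromo on an aromatic carbon.

For the measured compounds named here, no measured step exchanges one halogen for another, so nothing speaks directly to this change. Going by the values given here, the only step known, from compound 1 to compound 3, concerns different groups and showed no change; it bears on compound 4 only by analogy. Among the compounds with values here, compound 2 is also the single compound bearing a halogen, so its higher number cannot yet be tied to that group. The expectation for compound 4 is therefore a modest downward step, a number 15 percentage points lower from compound 2 to compound 4 (beyond the scatter), drifting toward the values of compound 1 and compound 3, with wide uncertainty. Compound 4 is thus estimated at 55%, between 35% and 75%.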

Compound 4, a percentage reported as activity, at one dose (the size of the read-out at that dose, not a potency): 40%
Estimate against measurement, compound 4: 15 percentage points above; measured number inside the range.
By their numbers in this assay, from the lowest: compounds 4, 1 and 3 (each within the scatter of the next); then compound 2.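

In this assay, among the compounds shown here, bromo and fluoro on this aromatic carbon are not interchangeable: exchanging one for the other gives a number 30 percentage points lower from compound 2 to compound 4 (beyond the scatter), whereas the only earlier step, no change at the digits printed from compound 1 to compound 3 (within the scatter), concerned other groups and moved nothing. The new step therefore gives the first sign that this series can respond to a change of a single atom on the aromatic ring, here at the carbon ortho to a group of 7 heavy atoms, even though neither bromo nor fluoro carries a hydrogen-bond donor, a hydrogen-bond acceptor or a net charge. Nothing measured here accounts for the size or direction of this step.

Chloro or iodo on the same carbon would show whether the read-out follows the identity of the halogen in any orderly way, and a methyl group or an amine there would show whether a halogen is needed at all. The compounds shown also leave open whether the same exchange would have a similar effect on another carbon of the aromatic ring, since this pair tests only one place, at one dose.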